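The source may report more compounds than this note shows. Statements on the series, on what has been measured and on what is new or still open speak of the compounds shown alone.

Measured so far:
compound 1 `CN(c1ccc(Oc2ncnc3sccc23)cc1)c1nccc(N2CCc3ccccc3C2)n1` — 68.4%
compound 2 `c1ccc2c(c1)CCN(c1ccnc(Nc3ccc(Oc4ncnc5ccsc45)cc3)n1)C2` — 54.9%
compound 3 `c1ccc2c(c1)CCN2c1ccnc(Nc2ccc(Oc3ncnc4sccc34)cc2)n1` — 2.81%

In a functional assay on A549 cells (Homo sapiens) for inhibition, read by MTT assay, with a stated time of 72 h, tested at 20 uM (a higher number here means more inhibition at the concentration tested (going by the name of the read-out), a lower number less inhibition), compound 3 gives 2.81%, the lowest of the three numbers; compound 2 gives 54.9%, a number beyond the scatter above it, and compound 1 gives 68.4%, further above still. Compound 4 `c1ccc2c(c1)CCN(c1ccnc(Nc3ccc(Oc4ncnc5sccc45)cc3)n1)C2` has not yet been measured in this assay. Compound 4 differs from compound 3 in one place: 1,2,3,4-tetrahydroisoquinolin-2-yl in place of 2,3-dihydro-1H-indol-1-yl on an aromatic carbon. Within the data shown here, no step between two measured compounds matches this change, so its size cannot be read off directly. Compound 4 carries the same group that compound 1 and compound 2 carry in that place, and both of those give numbers far above compound 3. The step of a number 57.2 percentage points higher from compound 3 to compound 4 (beyond the scatter) is therefore expected to be large and upward, well beyond the scatter. For compound 4 the estimate in this assay is 60%, expected to fall between 42% and 76%.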

Compound 4, a percentage reported as inhibition, at one concentration (the size of the read-out at that concentration, not a potency): 34%
Estimate against measurement, compound 4: 26 percentage points above; measured number below the stated range.
By their numbers in this assay, from the lowest: compound 3; then compound 4; then compound 2; then compound 1.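

In this assay, the position on an aromatic carbon next to the ring nitrogen now has a measured step: 1,2,3,4-tetrahydroisoquinolin-2-yl in place of 2,3-dihydro-1H-indol-1-yl gives a number 31.2 percentage points higher from compound 3 to compound 4 (beyond the scatter). This group does not set the level on its own, as compounds carrying it still differ with the arrangement of the group on the oxygen on an aromatic ring, a number 20.9 percentage points lower from compound 2 to compound 4 (beyond the scatter), and with hydrogen in place of methyl on the nitrogen on an aromatic ring, a number 34.4 percentage points lower from compound 1 to compound 4 (beyond the scatter). Three separate places in the series therefore each shift the number beyond the scatter.

Nothing measured here accounts for any of these steps. Going by these compounds, whether a morpholine or a piperidine at this position would hold the number near that of compound 4, and whether a methyl on the nitrogen would also raise the number with 2,3-dihydro-1H-indol-1-yl in place, stays open.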